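A few compounds are considered here, and "the series" means these few. Any claim that something is new, unique, unknown or untested is made for them only; others in the source may bear on it.

Of the compounds shown here, three sharing one core have been measured in a physicochemical assay for acid dissociation. Compound 1 `CC(C)Cc1ccc2c(NCCCNCc3ccco3)ccnc2c1` gives 9.47 in this assay. Compound 3 `COc1ccc(F)cc1CNCCCNc1ccnc2cc(CC(C)C)ccc12` gives 9.47, and the step between them is no change at the digits printed from compound 1 to compound 3 (within the scatter). Compound 2 `COc1cccc(CNCCCNc2ccnc3cc(-c4ccc(C(F)(F)F)cc4)ccc23)c1O` gives 9.47, so compound 2 stands level with compound 1 and compound 3 at the digits shown, all three within the usual scatter of one another.

Compound 4 `COc1cccc(CNCCCNc2ccnc3cc(CC4CCCCC4)ccc23)c1O` has not yet been measured. It differs from compound 2 in one place: cyclohexylmethyl in place of 4-(trifluoromethyl)phenyl on an aromatic carbon. For the measured compounds named here, the only measured step, no change at the digits printed from compound 1 to compound 3 (within the scatter), changed a group on a saturated chain carbon bound to an amine nitrogen, and it was no larger than the scatter. Going by the values given here, no measured step changes a group on the aromatic carbon of the core where compound 4 differs, so the evidence is thin. On what is known, the step from compound 2 to compound 4 is expected to be no change at the digits printed from compound 2 to compound 4 (within the scatter), which is no change beyond the scatter. Compound 4 is therefore estimated at 9.47, with a range from 9.15 to 9.8.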

Compound 4, acid dissociation constant: 9.47
Beside the measured number, compound 4's estimate shows no gap at the digits printed, and the stated range covers the measured number.
By their numbers in this assay, from the lowest: compounds 1, 2, 3 and 4 (each within the scatter of the next).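

In this assay, for the compounds shown here, the swap of 4-(trifluoromethyl)phenyl for cyclohexylmethyl on an aromatic carbon of the shared core gives no change at the digits printed from compound 2 to compound 4 (within the scatter) in the only measured step at this position. The earlier step touched a saturated chain carbon bound to an amine nitrogen, so this pair adds that a six-membered aromatic ring bearing fluorine and a six-membered non-aromatic ring of carbon only leave the read-out level here, even though the group entering has fewer heavy atoms than the one leaving. No separate measurement bears on why the number stays level.

As far as these compounds go, whether a group with an amine or a carboxylic acid on this carbon would shift the number remains open. A single pair also cannot show whether the same holds when the rest of the molecule differs.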